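The source may hold more compounds than are shown below. What is called first, only, known or untested is meant among the compounds shown, and "the series" means these compounds.

Working notes on the series. The shared core of compound 1 `CCOC(=O)c1c(-c2ccc(Cl)c(Cl)c2)cc(-c2ccccc2)nc1N1CCCCC1` carries a piperidin-1-yl group; in a functional assay on the whole organism (strain Wister albino) for inhibition, with Rattus norvegicus as the target, read by paw edema, with a stated time of 1 h, at a dose of 50 mg/kg by the intraperitoneal route (on this read-out lower numbers stand for less inhibition and higher numbers for more inhibition at the one dose given (going by the name of the read-out)), compound 1 gives 53.5%. Within the data shown here, compound 2 `CCOC(=O)c1c(-c2ccc(Cl)c(Cl)c2)cc(-c2ccccc2)nc1Nc1ccc(C)cc1` gives 59%, and the step of a number 5.5 percentage points higher from compound 1 to compound 2 (within the scatter) is the only single-change comparison measured so far. Compound 3 `CCOC(=O)c1c(-c2ccc(Cl)cc2)cc(-c2ccccc2)nc1Nc1ccc(Cl)cc1` gives 44.6%; its gap to compound 1 lies within the scatter, while its gap to compound 2 lies beyond the scatter, compound 3 being the smaller number. Compound 2 and compound 3 differ in two places, so their values show no single change.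

Compound 4 `CCOC(=O)c1c(-c2ccc(Cl)c(Cl)c2)cc(-c2ccccc2)nc1Nc1ccc(Cl)cc1` differs from compound 3 by chloro in place of hydrogen on an aromatic carbon. Among the measured compounds shown here, no measured step bears directly on this change; the step from compound 1 to compound 2 concerns a different site. Compound 1 and compound 2, both carrying 3,4-dichlorophenyl, sit near each other, and compound 4 shares that group. The step is therefore expected to be a number 6.4 percentage points higher from compound 3 to compound 4 (within the scatter), rising but not clearly beyond the scatter. Compound 4 is expected to give 51%, between 41% and 61%.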

Compound 4, a percentage reported as inhibition, in the whole organism at one dose (the size of the read-out at that dose, not a potency): 46.2%
For compound 4 the middle estimate is 4.8 percentage points above the measured one; the measured number falls inside the stated range.
By their numbers in this assay, from the lowest: compounds 3, 4, 1 and 2 (each within the scatter of the next, the first and the last beyond it).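

In this assay the added chloro, which turns 4-chlorophenyl into 3,4-dichlorophenyl, gives a number 1.6 percentage points higher from compound 3 to compound 4 (within the scatter) and so has no readable effect at this position on the aromatic ring. With 3,4-dichlorophenyl held fixed, the para substituent of the anilino group gains a first readable step, since chloro in place of methyl gives a number 12.8 percentage points lower from compound 2 to compound 4 (beyond the scatter) while replacing piperidin-1-yl with (4-chlorophenyl)amino gives a number 7.3 percentage points lower from compound 1 to compound 4 (within the scatter) and leaves those two amino groups unseparated. No measurement is available to account for these steps.

Still open, as far as these compounds go, is whether a methoxy group or a fluoro group on that anilino ring would hold the number nearer to that of compound 2 or that of compound 4. The compounds shown also leave open how a carboxylic acid or an amide in place of the ethyl ester would read in this assay on this core.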